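The source may report more compounds than this note shows. Statements on the series, on what has been measured and on what is new or still open speak of the compounds shown alone.

Compound 1 `CC/C(=C(/c1ccc(/C=C/C(=O)O)cc1)c1ccc2[nH]ncc2c1)c1ccccc1` gives 7.2 nM in a functional assay on MCF7 cells (Homo sapiens) for cytotoxicity, read by CellTiter-Glo, with a stated time of 5 days; a lower number here means a stronger inhibitor, a higher number a weaker inhibitor. Compound 2 `CCC/C(=C(/c1ccc(/C=C/C(=O)O)cc1)c1ccc2[nH]ncc2c1)c1ccccc1` gives 11 nM. Compound 3 `COC/C(=C(/c1ccc(/C=C/C(=O)O)cc1)c1ccc2[nH]ncc2c1)c1ccccc1` gives 88 nM.

Among these three, compound 3 stands highest in this assay; its nearest neighbour is compound 2, and compound 1 lies furthest from it. The step from compound 3 to compound 4 `O=C(O)/C=C/c1ccc(/C(=C(/CCO)c2ccccc2)c2ccc3[nH]ncc3c2)cc1` is a change of hydroxymethyl in place of methoxy on a saturated chain carbon bound to a double-bonded chain carbon.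

Within the data shown here, two measured steps bear on this position. Replacing methyl by methoxy on the saturated chain carbon bound to a double-bonded chain carbon gave a 12-fold higher number from compound 1 to compound 3 (1.09 log units; beyond the scatter), and replacing ethyl by methoxy at the same place gave an 8.0-fold higher number from compound 2 to compound 3 (0.90 log units; beyond the scatter). Both show that the alkyl chains of compound 1 and compound 2 give low numbers, while the oxygen-bearing methoxy of compound 3 gives a much higher one. Among the measured compounds shown here, compound 4 keeps an oxygen on the chain but moves it one bond further out and adds a hydrogen-bond donor; no measured pair shows that particular shift. The expectation is therefore that compound 4 will remain in the region of compound 3, with the step of a 1.5-fold lower number from compound 3 to compound 4 (0.17 log units; within the scatter) expected to be small, and its number in this assay is estimated at 60 nM, within a range from 15 nM to 250 nM.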

Compound 4, half-maximal inhibitory concentration: > 1000 nM
Compound 4 was reported as a limit (the forecaster's own chance of this, stated with the estimate: 5%); middle value at least 16-fold (1.22 log units) from the limit.
By their numbers in this assay, from the lowest: compounds 1 and 2 (each within the scatter of the next); then compound 3. At a limit, above all of these: compound 4.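

Compound 4 stands at a limit of this assay, not at a number: the limit of > 1000 nM in this assay, at which 1 of the 4 values shown sits. With the same atoms joined differently, this position proves sensitive not only to whether the chain carries an oxygen but also to how that oxygen is placed and whether it is capped, since the change from methoxymethyl to 2-hydroxyethyl gives an at least 11-fold higher number from compound 3 to compound 4 (1.05 log units; beyond the scatter). Measured against the two alkyl chains the gap is wider still, with an at least 90-fold higher number from compound 2 to compound 4 (1.95 log units; beyond the scatter) and an at least 130-fold higher number from compound 1 to compound 4 (2.14 log units; beyond the scatter), so the earlier picture of a single penalty for oxygen on this chain gives way to a clear difference between the two oxygen-bearing chains of compound 3 and compound 4.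

As far as these compounds go, how far beyond the limit compound 4 truly lies stays open, so each of these steps marks only a minimum size. The compounds shown also leave open how an amine, a nitrile or a longer chain ending in hydroxy would behave at this place, and so whether the result belongs to the hydroxy itself or to this particular chain.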